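This account rests on a few compounds, and the source may have more. Where it says the series, first, only, none or still open, it means among the compounds named here.

Two compounds share one core and differ only in the group on the far ring. Compound 1 `Cc1cc(C)c(-c2csc(NC(=O)/C=C/c3ccc(C(C)(C)C)cc3)n2)c(C)c1` carries tert-butyl there, and in a functional assay on MDA-MB-468 cells (Homo sapiens) for inhibition, read by MTT assay, with a stated time of 96 h (a lower number here means a stronger inhibitor, a higher number a weaker inhibitor), compound 1 gives only a limit, > 30000 nM, which is the limit of > 30000 nM in this assay, at which 1 of the 2 values shown sits. Compound 2 `Cc1cc(C)c(-c2csc(NC(=O)/C=C/c3ccc(C(F)(F)F)cc3)n2)c(C)c1` carries trifluoromethyl instead, and in this assay compound 2 gives 1530 nM. The step of an at least 19-fold lower number from compound 1 to compound 2 (1.29 log units; beyond the scatter) is therefore large. Compound 2 holds the only number shown; the other value is a limit.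

Compound 3 `Cc1cc(C)c(-c2csc(NC(=O)/C=C/c3ccc(C4CC4)cc3)n2)c(C)c1` takes this one step further: cyclopropyl in place of trifluoromethyl on an aromatic carbon. Cyclopropyl sits between tert-butyl and trifluoromethyl in bulk, and the step from tert-butyl to trifluoromethyl gave the large gain just described. Compound 3 is therefore expected to fall back part of the way, with an estimated step of a 3.9-fold higher number from compound 2 to compound 3 (0.59 log units; beyond the scatter). In this assay compound 3 is expected near 6000 nM, within the range 1500 nM to 30000 nM.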

Compound 3, half-maximal inhibitory concentration: 15700 nM
Beside the measured number, compound 3's estimate is 2.6-fold (0.42 log units) below it; low and high end bracket the measured number.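

Compound 2's gain over compound 1 might have come from simply removing tert-butyl, but compound 3 shows that it does not: in this assay, cyclopropyl in place of trifluoromethyl gives a 10-fold higher number from compound 2 to compound 3 (1.01 log units; beyond the scatter), so this position tells these groups apart sharply and compound 2 remains the most potent of the three. Cyclopropyl recovers little, if anything, of what trifluoromethyl provides, since the other step reads an at least 1.9-fold lower number from compound 1 to compound 3 (0.28 log units; that floor lies within the scatter) and compound 3 therefore cannot be firmly separated from compound 1. That step rests on a limit for compound 1, not on a number: the limit of > 30000 nM in this assay, at which 1 of the 3 values shown sits.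

On these data alone, whether a nitrile, a chlorine atom, a methoxy group or an amine at this position would match trifluoromethyl remains open. So does whether the same order of groups would hold on a different core.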